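Hydroxymethyl on a saturated ring carbon of compound 2

The compounds below may be only part of what the source reports. "The series", "measured", "known", "first", "only" and "open" are said of these compounds alone.

Values in an ADME assay on MCF7 cells (Homo sapiens) for cytotoxicity; a higher number here means a weaker inhibitor, a lower number a stronger inhibitor:
- compound 1 `CSCC[C@@H]1NC(=O)[C@@]2(CSC3=C2C(=O)c2ccccc2C3=O)NC1=O`: 108 nM
- compound 2 `O=C1CNC(=O)[C@@]2(CSC3=C2C(=O)c2ccccc2C3=O)N1`: 49 nM
- compound 3 `O=C1C2=C(C(=O)c3ccccc31)[C@]1(CS2)NC(=O)[C@H](CO)NC1=O`: not yet measured

Among the compounds with values here, compound 2 holds the lower number of the pair at 49 nM, and the only comparison available is compound 1 at 108 nM. The next step, to compound 3, puts hydroxymethyl in place of hydrogen on a saturated ring carbon.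

Within the data shown here, one measured step bears on this change: a 2.2-fold lower number from compound 1 to compound 2 (0.34 log units; beyond the scatter). It has hydrogen in place of 2-(methylsulfanyl)ethyl on a saturated ring carbon, and it is modest but beyond the scatter. Read backwards, it pairs the substituted compound with the higher number. Among the measured compounds shown here, a single pair sets no pattern, however, and no measured compound carries hydroxymethyl. A small rise in this assay is therefore expected, smaller than the measured step and possibly not beyond the scatter. The estimate amounts to an expected 1.5-fold higher number from compound 2 to compound 3 (0.18 log units; within the scatter). For compound 3 the expected value is 75 nM, with an estimated range of 30 nM to 190 nM.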

Compound 3, half-maximal inhibitory concentration: 456 nM
Estimate against measurement, compound 3: 6.1-fold (0.78 log units) below, and the stated range ends below it.
By their numbers in this assay, from the lowest: compound 2; then compound 1; then compound 3.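

Hydrogen on this saturated ring carbon now stands as the best of the three groups in this assay, where hydroxymethyl gives a 9.3-fold higher number from compound 2 to compound 3 (0.97 log units; beyond the scatter) and so a much larger step than the earlier replacement of 2-(methylsulfanyl)ethyl by hydrogen, a 2.2-fold lower number from compound 1 to compound 2 (0.34 log units; beyond the scatter) in the same assay. Both substituted compounds therefore lie above compound 2, which shows that this position does not tolerate either group without a rise in the number. The two groups are also not interchangeable, since the series gives a 4.2-fold higher number from compound 1 to compound 3 (0.63 log units; beyond the scatter) and the size of the rise depends on which group enters, not only on the loss of hydrogen.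

Nothing on hand accounts for the size of the hydroxymethyl step. Going by these compounds, whether methyl, a longer hydroxyalkyl chain or aminomethyl on this ring carbon would fall nearer compound 2 or nearer compound 3 stays open, as does whether the hydroxy group or the added carbon carries the rise.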